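Moving the Acid Group on a Glutamate Receptor Modulator

This account rests on a few compounds, and the source may have more. Where it says the series, first, only, none or still open, it means among the compounds named here.

Compound 1 `Cc1cc(C(=O)O)ccc1OCCCCOc1ccc(C(=O)CC(C)C)c(O)c1C` is measured in an assay on HEK293 cells for positive allosteric modulation of metabotropic glutamate receptor 2 (Rattus norvegicus), read by thallium flux, with a stated time of 2.5 min (on this read-out higher numbers stand for larger maximal responses and lower numbers for smaller maximal responses), where compound 1 gives 83.9%. Its only companion so far, compound 2 `Cc1cc(C(=O)O)ccc1OCCCCOc1ccc(C(=O)C(C)C)c(O)c1C`, gives 76.9%, and because a number 7 percentage points lower from compound 1 to compound 2 (within the scatter) the two cannot be set apart. Compound 3 `Cc1c(OCCCCOc2cccc(C(=O)O)c2)ccc(C(=O)CC(C)C)c1O` changes the other end of the chain: 3-carboxyphenyl in place of 4-carboxy-2-methylphenyl on an oxygen on a saturated carbon. Within the data shown here, the single measured step concerns only the group on the carbonyl carbon, so no measured step bears on this change and no direction is indicated. Compound 3 is therefore expected close to compound 1, with an estimated a number 5.9 percentage points lower from compound 1 to compound 3 (within the scatter), giving an estimate of 78%, ranging from 58% to 92%.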

Compound 3, largest response reached (reported as percent of maximum), in percent of the reference or control that the assay uses: 84.5%
For compound 3 the middle estimate is 6.5 percentage points below the measured one; the measured number falls inside the stated range.
By their numbers in this assay, from the lowest: compounds 2, 1 and 3 (each within the scatter of the next).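

Placing 3-carboxyphenyl in place of 4-carboxy-2-methylphenyl on an oxygen on a saturated carbon gives a number 0.6 percentage points higher from compound 1 to compound 3 (within the scatter) and so leaves the two compounds impossible to set apart. Among these compounds, this is the first measured step at this end of the chain, and it shows that the acid-bearing ring can lose its methyl group and have its carboxylic acid placed differently with no change beyond the scatter. Nothing available explains this result.

Whether this end needs a carboxylic acid at all remains open, since a tetrazole or primary amide in its place is not among the compounds shown. Going by these compounds, the effect of a shorter or longer chain linking the two rings also remains open.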